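A few compounds are considered here, and "the series" means these few. Any claim that something is new, unique, unknown or untested is made for them only; others in the source may bear on it.

Compound 1 `CCOC(=O)c1cnc(N2CCN(Cc3ccccc3C#N)CC2)nc1Oc1c(C)cc(-c2ccc(C#N)cc2)cc1C`: > 125000 nM
Compound 2 `CCOC(=O)c1cnc(N2CCN(Cc3ccccc3F)CC2)nc1Oc1c(C)cc(-c2ccc(C#N)cc2)cc1C`: > 125000 nM
Compound 3 `CCOC(=O)c1cnc(N2CCN(Cc3ccccc3Br)CC2)nc1Oc1c(C)cc(-c2ccc(C#N)cc2)cc1C`: > 125000 nM

In an ADME assay on MT4 cells (Homo sapiens) for cytotoxicity, read by MTT assay, with a stated time of 4 days (on this read-out higher numbers stand for lower toxicity in this test and lower numbers for higher toxicity in this test), compound 1 gives > 125000 nM, which is a limit of the assay and not a number. In this assay compound 2 likewise gives > 125000 nM, again a limit. Compound 3 gives > 125000 nM in this assay, once more a limit, so compound 3 stands at the same limit as the other two and has no measured number of its own.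

The three steps between the measured compounds are a step that the two limits leave unreadable from compound 1 to compound 2, a step that the two limits leave unreadable from compound 1 to compound 3 and a step that the two limits leave unreadable from compound 2 to compound 3; none of them can be read in size, since (the limit of > 125000 nM in this assay, at which 3 of the 3 values shown sit).

Compound 4 `CCOC(=O)c1cnc(N2CCN(Cc3ccc([N+](=O)[O-])cc3)CC2)nc1Oc1c(C)cc(-c2ccc(C#N)cc2)cc1C` is not yet measured. It differs from compound 3 by 4-nitrophenyl in place of 2-bromophenyl on a saturated chain carbon bound to an amine nitrogen in a ring. For the measured compounds named here, all three measured steps bear on a change of the group on the saturated chain carbon bound to the ring amine nitrogen, and all three are unreadable, so no size of step can be carried over; the expectation is therefore no step beyond the scatter, with the step from compound 3 to compound 4 expected as a step that the limit leaves unreadable from compound 3 to compound 4. Compound 4 is accordingly expected to give about 150000 nM in this assay, within a range of 70000 nM to 300000 nM, most probably reported again only as a limit.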

Compound 4, half-maximal cytotoxic concentration: > 125000 nM
Compound 4: only a limit was reported; the forecaster's own chance of this, stated with the estimate: 80%; the middle value lies beyond the limit too.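

In this assay compound 4 gives > 125000 nM, which is a limit and not a number. Its steps from compound 1, compound 2 and compound 3 cannot be read in size, because all four compounds end at the same point: the limit of > 125000 nM in this assay, at which 4 of the 4 values shown sit. The compounds shown leave open whether their benzyl groups differ at all in this test.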